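The source may report more compounds than this note shows. Statements on the series, on what has been measured and on what is new or still open speak of the compounds shown alone.

Working notes on the series.

The shared core is carried by compound 1 `CC(C)(C)OC(=O)c1cn(C[C@H]2CN(c3ccc(C4=CCS(=O)(=O)CC4)c(F)c3)C(=O)O2)nn1`, whose triazole ring bears a tert-butoxycarbonyl group. Among the compounds with values here, in an assay for binding affinity to Amine oxidase [flavin-containing] A (Homo sapiens) (a lower number here means a stronger inhibitor, a higher number a weaker inhibitor), compound 1 gives 3500 nM, the lowest of the three numbers so far. Compound 3 `Cc1cnnn1C[C@H]1CN(c2ccc(C3=CCS(=O)(=O)CC3)c(F)c2)C(=O)O1` gives 4500 nM and sits within the scatter of compound 1; compound 2 `Cc1cn(C[C@H]2CN(c3ccc(C4=CCS(=O)(=O)CC4)c(F)c3)C(=O)O2)nn1` gives 25000 nM and is the weakest of the three, its steps to both others lying beyond the scatter.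

The next compound, compound 4 `O=C1O[C@@H](Cn2ccnn2)CN1c1ccc(C2=CCS(=O)(=O)CC2)c(F)c1`, drops the group altogether: hydrogen in place of tert-butoxycarbonyl on an aromatic carbon

Within the data shown here, the one measured step that bears on this change is a 7.1-fold higher number from compound 1 to compound 2 (0.85 log units; beyond the scatter), where the tert-butoxycarbonyl was likewise removed and only a methyl put in its place. The step of a 5.6-fold lower number from compound 2 to compound 3 (0.74 log units; beyond the scatter) concerns a different place on the ring and does not bear on the change here. With the tert-butoxycarbonyl gone and nothing but hydrogen entering, a rise of at least the size seen for compound 2 is expected, in the direction of weaker inhibition. Compound 4 is therefore expected to give 25000 nM, within the range 8000 nM to 70000 nM, which means an expected step of a 7.1-fold higher number from compound 1 to compound 4 (0.85 log units; beyond the scatter).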

Compound 4, inhibition constant: 3400 nM
Beside the measured number, compound 4's estimate is 7.4-fold (0.87 log units) above it, and the stated range ends above it.
By their numbers in this assay, from the lowest: compounds 4, 1 and 3 (each within the scatter of the next); then compound 2.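

Taking the tert-butoxycarbonyl group off this aromatic carbon leaves the number in this assay within the scatter (  a 1.0-fold lower number from compound 1 to compound 4 (0.01 log units; within the scatter)), so at this level of binding that large group is not required on the shared core. The higher number of compound 2 therefore goes with the methyl on this carbon rather than with the loss of tert-butoxycarbonyl, as the step with hydrogen in place of that methyl shows (a 7.4-fold lower number from compound 2 to compound 4 (0.87 log units; beyond the scatter)), whereas the methyl as it stands in compound 3 makes no difference beyond the scatter (a 1.3-fold lower number from compound 3 to compound 4 (0.12 log units; within the scatter)). Nothing available gives a reason for this behaviour, in which the hydrogen and the much larger tert-butoxycarbonyl group read alike while the methyl stands apart.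

Still open, as far as these compounds go, is whether the methyl of compound 2 is an isolated case or the start of a trend, which an ethyl or a longer chain on this same carbon would test. From the compounds shown here alone, it is equally open whether a carboxylic acid or an amine at this place would stay level with compound 4 or move away from it.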